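The compounds below may be only part of what the source reports. "The series", "measured", "known", "first", "only" and "open" are said of these compounds alone.

Of the compounds shown here, three that share one core have been tested so far in a functional assay on the whole organism for antagonist activity, with Mus musculus as the target; on this read-out higher numbers stand for an effect only at larger amounts of compound and lower numbers for an effect already at smaller amounts. Compound 1 `CC(=O)N(C)CC#CCN1CCCC1` gives > 10 mg/kg, which is a limit and not a number. Compound 2 `COC(=O)N(C)CC#CCN1CCCC1` gives > 10 mg/kg, which is also a limit. Compound 3 `CCOC(=O)N(C)CC#CCN1CCCC1` gives > 100 mg/kg, and this too is a limit. Compound 3 therefore has no exact place on the scale of this assay.

Compound 4 `CN(C)C(=O)N(C)CC#CCN1CCCC1` has not yet been measured. It has dimethylamino in place of ethoxy on a carbonyl carbon, a swap that leaves the rest of compound 3 unchanged: dimethylamino in place of ethoxy on a carbonyl carbon.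

The closest evidence comes from swaps on a carbonyl carbon, namely a step that the two limits leave unreadable from compound 1 to compound 2 and a step that the two limits leave unreadable from compound 1 to compound 3. A third comparison is a step that the two limits leave unreadable from compound 2 to compound 3. None of these has a readable size, and none tests dimethylamino, so they give only weak guidance. The estimate leans toward lower numbers only because compound 3 gives > 100 mg/kg, which is a limit. With that uncertainty, the expected change is an at least 2.5-fold lower number from compound 3 to compound 4 (0.39 log units; beyond the scatter). For compound 4 the estimated dose is 40 mg/kg, with an expected range from 8 mg/kg to 200 mg/kg, and the assay may well report only a limit again.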

Compound 4, dose for half-maximal effect: > 10 mg/kg
Compound 4: only a limit was reported; the forecaster's own chance of this, stated with the estimate: 75%; the middle value does not contradict the limit.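

In this assay compound 4 gives > 10 mg/kg, which is a limit and not a number. Compound 1, compound 2 and compound 3 also carry only limits, and the steps from each of them to compound 4 cannot be read. The compounds shown leave open what dose gives a half-maximal effect for any of the four, and whether changing the group on the carbonyl carbon shifts that dose at all.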